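A Methylsulfonyl Replaces a Methyl, with Compound 2 at the Limit

This account rests on a few compounds, and the source may have more. Where it says the series, first, only, none or still open, it means among the compounds named here.

Compound 1 `C=C1CCC(c2csc(/C=C(\C)C(N)=O)c2)CC1` and compound 2 `C/C(=C\c1cc(-c2ccc(C)cc2)cs1)C(N)=O` have been tested in a functional assay on A549 cells (Homo sapiens) for cytotoxicity, read by CCK-8 assay, with a stated time of 24 h; a higher number here means a weaker inhibitor, a lower number a stronger inhibitor. Compound 1 gives only a limit of > 50000 nM. Compound 2 likewise gives only a limit of > 50000 nM. Together these two results define (the limit of > 50000 nM in this assay, at which 2 of the 2 values shown sit). Compound 3 `C/C(=C\c1cc(-c2ccc(S(C)(=O)=O)cc2)cs1)C(N)=O` differs from compound 2 by methylsulfonyl in place of methyl on an aromatic carbon. For the measured compounds named here, no measured step exists for such a change, so in this assay no shift beyond the scatter is expected. Compound 3 is therefore expected to give 80000 nM, within 20000 nM to 500000 nM. The step that the limit leaves unreadable from compound 2 to compound 3 is expected to be none beyond the scatter.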

Compound 3, half-maximal inhibitory concentration: > 50000 nM
Compound 3 gave a limit, no number; the forecaster's own chance of this, stated with the estimate: 85%; the middle value does not contradict the limit.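

For the compounds shown here, compound 2 and compound 3 both stand only as limits, so no step from one to the other can be read. The compounds shown leave open how far methylsulfonyl in place of methyl changes the read-out, if at all.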